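Removing a Trifluoromethyl Group: Compound 4 Expected

The compounds below may be only part of what the source reports. "The series", "measured", "known", "first", "only" and "open" are said of these compounds alone.

Measured compounds:
- compound 1 `COc1ccc(Cn2nc(-c3ccccc3)c3cc(C(=N)Nc4cccc(C(F)(F)F)c4)nc(NC4CCCCC4)c32)cc1`: "not determined" (no result reported)
- compound 2 `COc1ccc(Cn2cc3cc(C(=N)Nc4cccc(C(F)(F)F)c4)ncc3n2)cc1`: 12800 nM
- compound 3 `COc1ccc(Cn2nc(-c3ccccc3)c3cc(C(=N)Nc4cccc(C(F)(F)F)c4)nc(Nc4cc(OC)c(OC)c(OC)c4)c32)cc1`: "not determined" (no result reported)

Three compounds were tested in a functional assay on PC-3 cells (Homo sapiens) for cytotoxicity, read by MTT assay, with a stated time of 72 h; on this read-out higher numbers stand for weaker inhibition and lower numbers for stronger inhibition. Compound 1 returned "not determined" (no result reported), so no single number stands for it. The same holds for compound 3, which also returned "not determined" (no result reported). Only compound 2, built on a smaller core, gives a number: in this assay compound 2 gives 12800 nM, a weak effect. Among the measured compounds shown here, no step between measured compounds that differ in one place is available.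

Compound 4 `COc1ccc(Cn2nc(-c3ccccc3)c3cc(C(=N)Nc4ccccc4)nc(NC4CCCCC4)c32)cc1` is not yet measured. It differs from compound 1 by hydrogen in place of trifluoromethyl on an aromatic carbon, in words: hydrogen in place of trifluoromethyl on an aromatic carbon. For the measured compounds named here, with no number for compound 1 and no comparable step anywhere in the set, the direction and size of this change cannot be read from the data; a step of any size, or none beyond the scatter, remains possible. Taking the weak result of compound 2 as the only anchor, compound 4 is expected to fall around 9000 nM, between 1500 nM and 45000 nM.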

Compound 4, half-maximal inhibitory concentration: 1100 nM
Compound 4: the middle estimate sits 8.2-fold (0.91 log units) above what was measured; the whole stated range lies above it.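

Compound 1 has no single number to set beside compound 4, so no step can be read for swapping trifluoromethyl for hydrogen. The compounds shown leave open how that swap changes cytotoxicity. No supporting evidence bears on the value of compound 4.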